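The source may report more compounds than this note shows. Statements on the series, on what has been measured and on what is new or still open speak of the compounds shown alone.

Compounds measured so far:
- compound 1 `O=C(CN1CCN(c2nnc(Cc3ccncc3)c3ccccc23)CC1)Nc1cccc(F)c1`: 4.4 nM
- compound 2 `O=C(CN1CCN(c2nnc(Cc3ccncc3)c3ccccc23)CC1)Nc1ccc(F)c(Cl)c1`: 4 nM

In a functional assay on MDA-MB-231 cells (Homo sapiens) for cytotoxicity, read by MTT assay, with a stated time of 72 h (a lower number here means a stronger inhibitor, a higher number a weaker inhibitor), compound 2 gives 4 nM and sits level with compound 1 at 4.4 nM. Going by the values given here, the only measured step is a 1.1-fold lower number from compound 1 to compound 2 (0.04 log units; within the scatter).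

Compound 3 `O=C(CN1CCN(c2nnc(Cc3ccncc3)c3ccccc23)CC1)Nc1ccc(F)c(F)c1` turns 3-chloro-4-fluorophenyl into 3,4-difluorophenyl, with fluoro in place of chloro on an aromatic carbon, ortho to a fluoro group and meta to a large group: fluoro in place of chloro on an aromatic carbon.

That one step bears on this change only indirectly, since it also altered the substitution of this phenyl group. Its small size gives no reason to expect a large shift in this assay, though two compounds are thin evidence. The expected change is a 1.1-fold higher number from compound 2 to compound 3 (0.05 log units; within the scatter), with no step beyond the scatter anticipated and no direction favoured. Compound 3 is estimated at 4.5 nM, with an expected range of 1.8 nM to 11 nM.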

Compound 3, half-maximal inhibitory concentration: 0.84 nM
The estimate for compound 3 lay 5.4-fold (0.73 log units) above the measured number; the measured number lies below the stated range.
By their numbers in this assay, from the lowest: compound 3; then compounds 2 and 1 (each within the scatter of the next).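

In this assay, the halogen at this place on the phenyl group matters: fluoro in place of chloro gives a 4.8-fold lower number from compound 2 to compound 3 (0.68 log units; beyond the scatter), a step beyond the scatter, which the earlier pair gave no sign of. Fluoro in place of hydrogen on an aromatic carbon gives a 5.2-fold lower number from compound 1 to compound 3 (0.72 log units; beyond the scatter), so the 3,4-difluorophenyl group stands apart from both the 3-chloro-4-fluorophenyl group and the 3-fluorophenyl group, which remain level with each other. Nothing available accounts for these steps.

Open, on these data alone, is whether the gain is specific to the 3,4-difluorophenyl pattern or would extend to a methoxy, nitrile or trifluoromethyl group at the same place. Also open, as far as these compounds go, is whether the same steps hold on a core carrying a longer chain in place of the amide linker.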